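Replacing an oxetanyl carbamate by a difluoroethyl amide

This account rests on a few compounds, and the source may have more. Where it says the series, first, only, none or still open, it means among the compounds named here.

The measured compounds and their numbers:
Compound 1 `CCC1(OC(=O)N2CCC(Oc3ncnc(Oc4ccc(S(C)(=O)=O)nc4C)c3F)CC2)CC1` gives 22 nM in a functional assay on isolated protein for inhibition of Glucose-dependent insulinotropic receptor (Homo sapiens), read by HTRF and cAMP accumulation; on this read-out lower numbers stand for an effect already at smaller amounts and higher numbers for an effect only at larger amounts of compound.
Compound 2 `Cc1nc(S(C)(=O)=O)ccc1Oc1ncnc(OC2CCN(C(=O)OC3COC3)CC2)c1F` gives 326 nM in this assay.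
Compound 3 `Cc1nc(S(C)(=O)=O)ccc1Oc1ncnc(OC2CCN(C(=S)OC(C)C)CC2)c1F` gives 69.9 nM in this assay.

Compound 2 stands at the highest number of the three. The step of a 15-fold higher number from compound 1 to compound 2 (1.17 log units; beyond the scatter) lies beyond the scatter, as does the step of a 4.7-fold lower number from compound 2 to compound 3 (0.67 log units; beyond the scatter); both show that the oxetan-3-yl group on the oxygen of the carbamate goes with the weakest result in this small set.

Compound 4 `Cc1nc(S(C)(=O)=O)ccc1Oc1ncnc(OC2CCN(C(=O)C(C)(F)F)CC2)c1F` has not yet been measured. Its change from compound 2 is 1,1-difluoroethyl in place of (oxetan-3-yl)oxy on a carbonyl carbon; the (oxetan-3-yl)oxy group leaves and a 1,1-difluoroethyl group enters on the carbonyl carbon. The step from compound 2 to compound 3 bears most directly on this, since there too the oxetane leaves and a group without a ring enters; it gave a modest lower number. The step from compound 1 to compound 2 points the same way. A modest step towards a lower number is therefore expected for compound 4, about a 4.1-fold lower number from compound 2 to compound 4 (0.61 log units; beyond the scatter), with compound 4 estimated at 80 nM within a range from 30 nM to 250 nM.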

Compound 4, half-maximal effective concentration: 37 nM
For compound 4 the middle estimate is 2.2-fold (0.33 log units) above the measured one; measured number inside the range.
By their numbers in this assay, from the lowest: compounds 1, 4 and 3 (each within the scatter of the next, the first and the last beyond it); then compound 2.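

Until now every group on the carbon at this place was attached through an oxygen. The 1,1-difluoroethyl group is not, and in this assay putting it in place of (oxetan-3-yl)oxy gives an 8.8-fold lower number from compound 2 to compound 4 (0.95 log units; beyond the scatter) and so shows that neither that oxygen nor the oxetane ring is needed for a low number. The amide also keeps level with the two other groups: a 1.7-fold higher number from compound 1 to compound 4 (0.23 log units; within the scatter) and a 1.9-fold lower number from compound 3 to compound 4 (0.28 log units; within the scatter) both lie within the scatter and so show no real difference.

Going by these compounds, whether a plain ethyl group or a trifluoromethyl group on the same carbonyl carbon would do as well, and so whether the fluorine atoms matter at all, stays open. Nothing measured here explains the size of the step.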